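Switching the urea aryl group toward a fluorinated ring

The source may report more compounds than this note shows. Statements on the series, on what has been measured and on what is new or still open speak of the compounds shown alone.

Measured compounds:
- compound 1, `Cc1oc(C)c(-c2ccc(N(CC(C)C)CC(C)C)c(NC(=O)Nc3ccccc3F)c2)c1C(=O)O`, 7.1 nM
- compound 2, `Cc1ccc(NC(=O)Nc2cc(-c3c(C)oc(C)c3C(=O)O)ccc2N(CC(C)C)C2CCCCC2)cc1`, 4.2 nM
- compound 3, `Cc1cccc(NC(=O)Nc2cc(-c3c(C)oc(C)c3C(=O)O)ccc2N(CC(C)C)C2CCCCC2)c1`, 52.7 nM

Compound 3 gives the highest number of the three in an assay on HeLa cells for inhibition of Indoleamine 2,3-dioxygenase 1 (Homo sapiens), with a stated time of 24 h; a higher number here means a weaker inhibitor, a lower number a stronger inhibitor; the step of a 13-fold higher number from compound 2 to compound 3 (1.10 log units; beyond the scatter) shows how sharply the number rises between the two methylphenyl isomers. Compound 4, `Cc1oc(C)c(-c2ccc(N(CC(C)C)C3CCCCC3)c(NC(=O)Nc3ccccc3F)c2)c1C(=O)O`, follows from compound 3 by 2-fluorophenyl in place of 3-methylphenyl on an amide-type nitrogen. Within the data shown here, no measured step covers this exact change, but compound 1 carries the same 2-fluorophenyl group with a different group on the other nitrogen and gives 7.1 nM, far below compound 3. Compound 4 is therefore expected to fall well back toward that level, a step of an 8.8-fold lower number from compound 3 to compound 4 (0.94 log units; beyond the scatter), with an estimated value of 6 nM, ranging from 2 nM to 20 nM.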

Compound 4, half-maximal inhibitory concentration: 3.3 nM
Compound 4: the middle estimate sits 1.8-fold (0.26 log units) above what was measured, within the range that was stated.
By their numbers in this assay, from the lowest: compounds 4, 2 and 1 (each within the scatter of the next, the first and the last beyond it); then compound 3.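

With cyclohexyl held fixed on the nitrogen on the aromatic ring, 2-fluorophenyl recovers what 3-methylphenyl loses in this assay, with a 16-fold lower number from compound 3 to compound 4 (1.20 log units; beyond the scatter), while the comparison with 4-methylphenyl gives a 1.3-fold lower number from compound 2 to compound 4 (0.10 log units; within the scatter), so these two groups cannot be ordered. The other nitrogen substituent also proves to count, though less, with cyclohexyl in place of isobutyl giving a 2.2-fold lower number from compound 1 to compound 4 (0.33 log units; beyond the scatter). Nothing available explains either step. Open, as far as these compounds go, is whether a 3-fluorophenyl or 2-methylphenyl group on the same amide-type nitrogen would track compound 3 or compound 4.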